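Anilinonicotinoyl sulfonyl hydrazides: first dichlorophenyl variant

The source may hold more compounds than are shown below. What is called first, only, known or untested is meant among the compounds shown, and "the series" means these compounds.

Measured so far:
compound 1 `CC(=O)Nc1ccc(S(=O)(=O)NNC(=O)c2cccnc2Nc2ccc(Cl)cc2)cc1` — > 100000 nM
compound 2 `O=C(NNS(=O)(=O)c1ccc(F)cc1)c1cccnc1Nc1ccc(Cl)cc1Cl` — > 100000 nM

Both compounds have been run in a functional assay on NCI-H460 cells (Homo sapiens) for antiproliferative activity; a lower number here means a stronger inhibitor of growth, a higher number a weaker inhibitor of growth. For compound 1 the value is not a number but a limit of the assay, > 100000 nM. For compound 2 the result is likewise only a limit, > 100000 nM. Both values therefore sit at the limit of > 100000 nM in this assay, at which 2 of the 2 values shown sit. Within the data shown here, compound 1 thus stands at the upper bound of what this assay reports, and since neither measured compound gives a number, no step between them can be sized.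

Compound 3 `O=C(NNS(=O)(=O)c1ccc(Cl)cc1Cl)c1cccnc1Nc1ccc(Cl)cc1` has not yet been measured. It differs from compound 1 in one place: 2,4-dichlorophenyl in place of 4-acetamidophenyl on a sulfonyl sulfur. Compound 2, which also carries a halogenated phenyl on the sulfonyl sulfur, gave only a limit. With no numbered value to start from, the step from compound 1 to compound 3 is expected to be none beyond the scatter, a number no higher from compound 1 to compound 3 (the limit leaves the size open). Compound 3 is expected at 100000 nM, within 20000 nM to 300000 nM, and most likely reported again only as a limit.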

Compound 3, concentration for total growth inhibition: 100000 nM
Estimate against measurement, compound 3: no gap at the digits printed; low and high end bracket the measured number.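

In this assay, among these compounds, compound 3 gives 100000 nM, the first plain number. With 4-acetamidophenyl leaving the sulfonyl sulfur and 2,4-dichlorophenyl entering, the acetamide and its hydrogen-bond donor and acceptor are gone, and the change gives a number no higher from compound 1 to compound 3 (the limit leaves the size open). A halogenated phenyl at this place, with no acetamide, therefore still leaves the series at the weak edge of what this assay reports: the limit of > 100000 nM in this assay, at which 2 of the 3 values shown sit.

Still open, going by these compounds, is whether any other group on the sulfonyl sulfur, such as a methyl or a phenyl carrying an amine or a carboxylic acid, would give a value clearly lower than that of compound 3. Also open, on these data alone, is what the chlorines on the anilino ring contribute, since compound 2 and compound 3 differ in more than one place and cannot be compared directly.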